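Extending the amine side chain on the benzolactam core

The source may hold more compounds than are shown below. What is called first, only, known or untested is meant among the compounds shown, and "the series" means these compounds.

Compound 1 `N[C@@H]1CCc2ccccc2N(Cc2ccc(-c3ccccc3-c3nn[nH]n3)cc2)C1=O` gives 9 uM in a functional assay on cells (Pituitary gland cell) with growth hormone secretagogue receptor type 1 (Rattus norvegicus) as the target; a higher number here means that more compound is needed for the effect, a lower number that less compound is needed. For the measured compounds named here, compound 2 `CC[C@@H](N)C(=O)N[C@@H]1CCc2ccccc2N(Cc2ccc(-c3ccccc3-c3nn[nH]n3)cc2)C1=O` gives 0.3 uM, the lowest of the two numbers so far. The step of a 30-fold lower number from compound 1 to compound 2 (1.48 log units; beyond the scatter) shows that attaching the amino-acyl group helped strongly. Compound 3 `CC(C)(CC(=O)N[C@@H]1CCc2ccccc2N(Cc2ccc(-c3ccccc3-c3nn[nH]n3)cc2)C1=O)NCCN` differs from compound 2 by 2-((2-aminoethyl)amino)-2-methylpropyl in place of 1-aminopropyl on a carbonyl carbon. Going by the values given here, no measured step tests such a swap of one amino-acyl group for another, so the direction is open; only the gain from compound 1 to compound 2 suggests the acyl group matters. Compound 3 is expected to give 0.5 uM (range 0.1 uM to 2.5 uM), a step of a 1.7-fold higher number from compound 2 to compound 3 (0.22 log units; within the scatter) estimated within or near the scatter.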

Compound 3, concentration for half-maximal effect: 230 uM
Beside the measured number, compound 3's estimate is 460-fold (2.66 log units) below it; the whole stated range lies below it.
By their numbers in this assay, from the lowest: compound 2; then compound 1; then compound 3.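

The acyl group on this amine nitrogen does not help whatever it carries: in this assay, 2-((2-aminoethyl)amino)-2-methylpropyl in place of 1-aminopropyl on the carbonyl carbon gives a 770-fold higher number from compound 2 to compound 3 (2.88 log units; beyond the scatter). Set against the bare amine, the larger group even loses ground, with a 26-fold higher number from compound 1 to compound 3 (1.41 log units; beyond the scatter), so acylation alone does not account for the earlier gain. No measurement at hand gives a reason for this loss. Still open, going by these compounds, is which part of the larger group matters, and how a smaller 1-aminoethyl or a 1-hydroxypropyl group would fare on the same carbonyl carbon.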